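Repositioning the carboxylate on a mGlu2 potentiator scaffold

This account rests on a few compounds, and the source may have more. Where it says the series, first, only, none or still open, it means among the compounds named here.

Compound 1 `Cc1cc(C(=O)O)ccc1OCCCCOc1ccc(C(=O)CC(C)C)c(O)c1C`: 192 nM
Compound 2 `Cc1c(OCCCCOc2ccc(C(=O)O)cc2)ccc(C(=O)CC(C)C)c1O`: 122 nM
Compound 3 `Cc1c(OCCCCOc2ccc(C(=O)O)cc2Cl)ccc(C(=O)CC(C)C)c1O`: 96 nM

In an assay on HEK293 cells for positive allosteric modulation of metabotropic glutamate receptor 2 (Rattus norvegicus), read by thallium flux, with a stated time of 2.5 min (a higher number here means that more compound is needed for the effect, a lower number that less compound is needed), compound 3 gives the lowest of the three numbers, though the gaps a 1.3-fold lower number from compound 2 to compound 3 (0.10 log units; within the scatter) and a 2.0-fold lower number from compound 1 to compound 3 (0.30 log units; within the scatter) both sit within the scatter. Compound 4 `Cc1ccc(C(=O)O)cc1OCCCCOc1ccc(C(=O)CC(C)C)c(O)c1C` carries 5-carboxy-2-methylphenyl in place of 4-carboxy-2-chlorophenyl on an oxygen on a saturated carbon. On these data alone, the measured steps only vary the substituent beside the ether, as in a 1.6-fold lower number from compound 1 to compound 2 (0.20 log units; within the scatter); none moves the carboxy group itself, so the shift from a 4-carboxy to a 5-carboxy pattern is untested. On these three compounds the expectation for a 2.7-fold higher number from compound 3 to compound 4 (0.43 log units; beyond the scatter) is a modest rise with wide uncertainty. Compound 4 is therefore estimated at 260 nM, within 80 nM to 900 nM.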

Compound 4, half-maximal effective concentration: 454 nM
The estimate for compound 4 lay 1.7-fold (0.24 log units) below the measured number; the measured number falls inside the stated range.
By their numbers in this assay, from the lowest: compounds 3, 2 and 1 (each within the scatter of the next); then compound 4.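

In this assay, moving the carboxy group alone, with 5-carboxy-2-methylphenyl in place of 4-carboxy-2-methylphenyl on the oxygen, gives a 2.4-fold higher number from compound 1 to compound 4 (0.37 log units; beyond the scatter). Among the compounds shown here, this shows that the carboxy position matters here, as do a 3.7-fold higher number from compound 2 to compound 4 (0.57 log units; beyond the scatter) and a 4.7-fold higher number from compound 3 to compound 4 (0.67 log units; beyond the scatter), whereas the earlier steps, which kept the 4-carboxy pattern, all stayed within the scatter. Nothing presented here accounts for this shift. On these data alone, it remains open whether chloro in place of the methyl of 5-carboxy-2-methylphenyl would change the number, and how a tetrazole would compare with the carboxylic acid.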